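From Compound 1 to Compound 3: An Expected Cytotoxicity Value

The source may report more compounds than this note shows. Statements on the series, on what has been measured and on what is new or still open speak of the compounds shown alone.

Measured compounds:
compound 1 `COc1cnc2ccc(=O)n(CCN3CCC(NC(=S)NCc4ccc(Cl)cc4)CC3)c2c1` — 29.5%
compound 2 `COc1ccc(CNC(=S)NC2CCN(CCn3c(=O)ccc4ncc(OC)cc43)CC2)cc1` — 19.4%

In an ADME assay on RAW264.7 cells (Mus musculus) for cytotoxicity, read by MTT assay, with a stated time of 48 h, tested at 100 uM (on this read-out lower numbers stand for less inhibition and higher numbers for more inhibition at the one concentration tested (going by the name of the read-out)), compound 1 gives 29.5%, the higher of the two numbers. Compound 2 gives 19.4%. Among the measured compounds shown here, the only measured step is a number 10.1 percentage points lower from compound 1 to compound 2 (beyond the scatter). Compound 3 `COc1cnc2ccc(=O)n(CCN3CCC(NC(=O)NCc4ccc(Cl)cc4)CC3)c2c1` differs from compound 1 by a group of 11 heavy atoms (8 carbon, 1 nitrogen, 1 oxygen, 1 chlorine; one six-membered aromatic ring of carbon only) in place of a group of 11 heavy atoms (8 carbon, 1 nitrogen, 1 sulfur, 1 chlorine; one six-membered aromatic ring of carbon only), on an amine nitrogen. For the measured compounds named here, no measured step touches this part of the molecule, so the one known step offers no direct guide. Compound 3 is estimated at 22%, within 8% to 38%, an expected step of a number 7.5 percentage points lower from compound 1 to compound 3 (within the scatter) that may well fall within the scatter.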

Compound 3, a percentage reported as inhibition, at one concentration (the size of the read-out at that concentration, not a potency): 40.9%
Compound 3: the middle estimate sits 18.9 percentage points below what was measured; the measured number lies above the stated range.
By their numbers in this assay, from the lowest: compound 2; then compound 1; then compound 3.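

Changing only sulfur to oxygen in the group on the amine nitrogen, which gives the (4-chlorobenzyl)carbamoyl group, yields a number 11.4 percentage points higher from compound 1 to compound 3 (beyond the scatter) in this assay and shows that the number responds to this part of the molecule as well as to the aromatic substituent. This step runs upward, unlike the methoxy change, which gave a number 10.1 percentage points lower from compound 1 to compound 2 (beyond the scatter) on the same starting compound. Nothing shown accounts for the step.

From the compounds shown here alone, whether methoxy in place of chloro would also lower the number on compound 3 stays open. Equally open, going by these compounds, is how a guanidine on this amine nitrogen would read.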